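The source may hold more compounds than are shown below. What is called first, only, known or untested is meant among the compounds shown, and "the series" means these compounds.

In an ADME assay on MT4 cells (Homo sapiens) for cytotoxicity, read by MTT assay (a lower number here means that less compound is tolerated, a higher number that more compound is tolerated), compound 3 `Cc1cc(C)cc(S(=O)(=O)c2c(C(=O)NC(c3ccc(Cl)cc3)C3CC3)[nH]c3ccc(Cl)cc23)c1` reads > 47300 nM, which is a limit and not a number. Compound 1 `Cc1cc(C)cc(S(=O)(=O)c2c(C(=O)NCC(=O)NCc3ccncc3)[nH]c3ccc(Cl)cc23)c1` reads > 48900 nM, also a limit. Compound 2 `Cc1cc(C)cc(S(=O)(=O)c2c(C(=O)NCc3n[nH]c4ccccc34)[nH]c3ccc(Cl)cc23)c1` reads > 50700 nM, a limit as well. All three readings are therefore limits, and compound 3 cannot be placed in an order with the other two.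

Compound 4 `Cc1cc(C)cc(S(=O)(=O)c2c(C(=O)NC(C)C(=O)NCc3ccncn3)[nH]c3ccc(Cl)cc23)c1` differs from compound 3 by one change: a group of 12 heavy atoms (8 carbon, 3 nitrogen, 1 oxygen; one six-membered aromatic ring with 2 hetero atoms) in place of a group of 11 heavy atoms (10 carbon, 1 chlorine; one three-membered non-aromatic ring of carbon only, one six-membered aromatic ring of carbon only), on an amide-type nitrogen. The change sits on an amide-type nitrogen whose other neighbour is the carbonyl carbon. The measured steps at this place are a step that the two limits leave unreadable from compound 1 to compound 3, a step that the two limits leave unreadable from compound 2 to compound 3 and a step that the two limits leave unreadable from compound 1 to compound 2. None of them has a size that can carry over to the new step.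

The expectation leans on compound 1, whose group also holds a six-membered aromatic ring with a hetero atom, and its > 48900 nM is again a limit. No step beyond the scatter is expected in this assay, in either direction. The expected step is a number no higher from compound 3 to compound 4 (the limit leaves the size open). The estimated value for compound 4 is 47000 nM, within an expected range from 20000 nM to 60000 nM, and a further limit is the likeliest report.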

Compound 4, half-maximal cytotoxic concentration: 28100 nM
For compound 4 the middle estimate is 1.7-fold (0.22 log units) above the measured one; the measured number falls inside the stated range.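

Compound 4 is the first compound shown with this change on the amide-type nitrogen to give a number rather than a limit in this assay, so a group at this place can bring the reading inside the range of the assay, while the steps among compound 1, compound 2 and compound 3 remain unreadable. That number sets a floor under each new step, with an at least 1.6-fold lower number from compound 3 to compound 4 (0.22 log units; that floor lies within the scatter), an at least 1.8-fold lower number from compound 2 to compound 4 (0.25 log units; that floor lies within the scatter) and an at least 1.7-fold lower number from compound 1 to compound 4 (0.24 log units; that floor lies within the scatter), so the direction is lower in each case, but none of the three floors by itself shows a change beyond the scatter. Nothing given here is a measured property that bears on why this group gives a number.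

The compounds shown leave open whether the six-membered aromatic ring with 2 hetero atoms or another part of the entering group goes with the number, and how far the true readings of the three compounds with limits lie from it. On these data alone, how a group ending in a carboxylic acid or an amine, or one with a longer chain, would read on this nitrogen also stays open.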